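The source may report more compounds than this note shows. Statements on the series, on what has been measured and on what is new or still open speak of the compounds shown alone.

Measured in a functional assay on NCI-H630 cells (Homo sapiens) for cytotoxicity, read by sulforhodamine B assay, with a stated time of 5 days; a lower number here means a stronger inhibitor, a higher number a weaker inhibitor:
Compound 1 `O=C(CCCCCCCCCCCc1ccccc1)CC(=O)N[C@H]1CCOC1=O`: 33000 nM
Compound 2 `O=C(CCCc1ccccc1)CC(=O)N[C@H]1CCOC1=O`: > 100000 nM, a limit
Compound 3 `O=C(CCCCCc1ccccc1)CC(=O)N[C@H]1CCOC1=O`: 44000 nM

Among the compounds with values here, compound 1 has one of only two actual numbers in this set, and it lies within the scatter of the other, from compound 3. The result for compound 2 is a limit, not a number.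

Compound 4 `O=C(CCCCCCCCCCc1ccccc1)CC(=O)N[C@H]1CCOC1=O` has not yet been measured. It differs from compound 1 by phenyl in place of benzyl on a saturated chain carbon, ten or more bonds along the chain from a carbonyl carbon.

With compound 3 at 44000 nM and compound 1 at 33000 nM, no change beyond the scatter is expected in this assay. The estimated step of a 1.1-fold higher number from compound 1 to compound 4 (0.03 log units; within the scatter) is expected to remain within the scatter. For compound 4, the expected value is 35000 nM, with an estimated range of 18000 nM to 65000 nM.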

Compound 4, half-maximal inhibitory concentration: 23000 nM
The estimate for compound 4 lay 1.5-fold (0.18 log units) above the measured number; measured number inside the range.
By their numbers in this assay, from the lowest: compounds 4, 1 and 3 (each within the scatter of the next). At a limit, above all of these: compound 2.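

In this assay, phenyl in place of benzyl on a saturated chain carbon, ten or more bonds along the chain from a carbonyl carbon, gives a 1.4-fold lower number from compound 1 to compound 4 (0.16 log units; within the scatter). Within the data shown here, this is the first step here between compounds that differ in one place, and it shows that this change at this position leaves the number within the scatter. The compounds shown give no cause for the step.

As far as these compounds go, whether a longer chain would move the number beyond the scatter stays open. So does the effect of an amine or a carboxylic acid in place of phenyl at this position.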